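The source may hold more compounds than are shown below. What is called first, only, known or untested is meant among the compounds shown, and "the series" means these compounds.

Measured so far in an ADME assay on MDCK cells (Canis lupus familiaris) for cytotoxicity, read by MTT assay, with a stated time of 24 h; on this read-out lower numbers stand for higher toxicity in this test and higher numbers for lower toxicity in this test:
- compound 1 `O=[N+]([O-])c1ccc(S(=O)(=O)NCc2ccoc2)cc1`: > 236000 nM (a limit)
- compound 2 `Cc1cc(CNS(=O)(=O)c2ccc([N+](=O)[O-])cc2)c(C)s1`: > 204000 nM (a limit)

In this assay compound 2 stands at > 204000 nM, which is a limit and not a number. Neither measured compound has a numerical value yet, so the series offers only limits as a reference.

The next compound is compound 3 `Cc1cc(CNS(=O)(=O)c2ccc(C#N)cc2)c(C)s1`, with the change (cyano in place of nitro on an aromatic carbon). In words, cyano replaces nitro on an aromatic carbon of a six-membered aromatic ring of carbon only, para to a large group.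

Going by the values given here, only one measured step exists, a step that the two limits leave unreadable from compound 1 to compound 2. It concerns a different place in the molecule and gives no size to carry over. Among the compounds with values here, no measured step covers the exchange of nitro for cyano. With no size to draw on, no direction can be assigned, and no step beyond the scatter is expected in this assay. The expected step is a step that the limit leaves unreadable from compound 2 to compound 3. A reading reported only as a limit is also expected.

For compound 3 the estimated value is 220000 nM, with an expected range of 110000 nM to 440000 nM.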

Compound 3, half-maximal cytotoxic concentration: > 217000 nM
Compound 3: only a limit was reported; the forecaster's own chance of this, stated with the estimate: 80%; the middle value lies beyond the limit too.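

In this assay compound 3 gives > 217000 nM, which is a limit and not a number. Compound 2 also stands only at a limit, so no step can be read for cyano in place of nitro between compound 2 and compound 3. The compounds shown leave open whether either exchange alters the half-maximal cytotoxic concentration at all.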